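A few compounds are considered here, and "the series" means these few. Any claim that something is new, unique, unknown or untested is made for them only; others in the source may bear on it.

Working notes on the series. In an ADME assay on microsomes from liver (Mus musculus, strain CD1) for metabolic stability, read by HPLC, using NADPH, with a stated time of 30 min, tested at 0.5 uM (a lower number here means slower removal, a higher number faster removal of the compound), compound 1 `CC(C)(C)[C@H]1CC[C@@H](n2c(=O)[nH]c3ncc(N)cc3c2=O)CC1` gives 1.6 mL.min-1.g-1 and compound 2 `CC[C@H]1CC[C@H](n2c(=O)[nH]c3ncc(N)cc3c2=O)CC1` gives 0.9 mL.min-1.g-1, two numbers within the scatter of each other. Compound 3 `CC[C@H]1CC[C@@H](n2c(=O)[nH]c3ncc(N)cc3c2=O)CC1` is not yet measured and is compared with compound 2: the two compounds have the same atoms and bonds and differ only in configuration as drawn: 2 of 2 stereo elements differ (all stereocentres are inverted: mirror images); a stereocentre at a saturated ring carbon is drawn r in compound 2 and s in compound 3; a stereocentre at a saturated ring carbon is drawn r in compound 2 and s in compound 3. Among the compounds with values here, no measured pair differs in configuration alone, so the data do not size such a change. The expected result is a 1.1-fold higher number from compound 2 to compound 3 (0.05 log units; within the scatter), a step not beyond the scatter, with no direction favoured. For compound 3, the estimated value in this assay is 1 mL.min-1.g-1, with an expected range of 0.5 mL.min-1.g-1 to 2.2 mL.min-1.g-1.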

Compound 3, intrinsic clearance in microsomes: 1.7 mL.min-1.g-1
Compound 3: the middle estimate sits 1.7-fold (0.23 log units) below what was measured; measured number inside the range.
By their numbers in this assay, from the lowest: compounds 2, 1 and 3 (each within the scatter of the next).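

In this assay the series now holds a pair that sizes a change of configuration alone: inverting both stereocentres gives a 1.9-fold higher number from compound 2 to compound 3 (0.28 log units; within the scatter) and so sets no difference beyond the scatter, with this reading resting on one fact: the fact that compounds 2 and 3 differ only in the configuration as drawn. With the configuration as drawn held, ethyl in place of tert-butyl on a saturated ring carbon gives a 1.1-fold higher number from compound 1 to compound 3 (0.03 log units; within the scatter) and likewise shows no step beyond the scatter at this position. Open, from the compounds shown here alone, is whether an amine, a carboxylic acid or a longer chain on that ring carbon would give a step beyond the scatter.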